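Fluoro to bromo on the shared core

This account rests on a few compounds, and the source may have more. Where it says the series, first, only, none or still open, it means among the compounds named here.

- compound 1 `O=C(CCCCCCN1C(=O)/C(=N\O)c2cc(Cl)ccc21)NO`: 850 nM
- compound 2 `CO/N=C1/C(=O)N(CCCCCCC(=O)NO)c2ccc(F)cc21`: 1150 nM

In a functional assay on PC-3 cells (Homo sapiens) for antiproliferative activity, read by sulforhodamine B assay, with a stated time of 48 h (on this read-out higher numbers stand for weaker inhibition and lower numbers for stronger inhibition), compound 2 gives 1150 nM, which lies within the scatter of compound 1. Compound 3 `CO/N=C1/C(=O)N(CCCCCCC(=O)NO)c2ccc(Br)cc21` carries bromo in place of fluoro on an aromatic carbon. Going by the values given here, the measured compounds include no pair differing in one place, so the data do not show the size of such a change. No step beyond the scatter is expected in this assay, and neither direction is favoured. The expected step is a 1.2-fold lower number from compound 2 to compound 3 (0.06 log units; within the scatter). The estimate for compound 3 is 1000 nM, with a range from 420 nM to 2400 nM.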

Compound 3, half-maximal inhibitory concentration: 8910 nM
For compound 3 the middle estimate is 8.9-fold (0.95 log units) below the measured one; measured number above the stated range.
By their numbers in this assay, from the lowest: compounds 1 and 2 (each within the scatter of the next); then compound 3.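

In this assay bromo in place of fluoro on this aromatic carbon gives a 7.7-fold higher number from compound 2 to compound 3 (0.89 log units; beyond the scatter) and so shows that the position is not indifferent to the choice of halogen. Going by these compounds alone, this is the only one-place step, and it puts a clear limit on exchanging fluoro for bromo here. Nothing at hand accounts for the size of this step. Compound 1 carries chloro but also differs in a second place, leaving the three halogens unranked on one background. As far as these compounds go, how a methoxy, a nitrile or an amine on this carbon would read remains open.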